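This account rests on a few compounds, and the source may have more. Where it says the series, first, only, none or still open, it means among the compounds named here.

Compound 1 `CCCCCCC(CCCOc1cc(C)ccc1C)C(=O)O` gives in a functional assay on thoracic aorta (Mus musculus, strain C57Bl6) for inhibition (on this read-out higher numbers stand for an effect only at larger amounts of compound and lower numbers for an effect already at smaller amounts), 10 uM.
Compound 2 `Cc1ccc(C)c(OCCCCC(=O)O)c1` gives in this assay 100 uM.

Among the measured compounds shown here, compound 2 stands highest of the two numbers in this assay; the only measured step, a 10-fold higher number from compound 1 to compound 2 (1.00 log units; beyond the scatter), runs from compound 1 and is a modest one. Compound 3 `Cc1ccc(C)c(OCCCCCC(=O)O)c1` differs from compound 2 by carboxymethyl in place of carboxy on a saturated chain carbon, four bonds along the chain from an oxygen on an aromatic ring. For the measured compounds named here, no measured step concerns a change of this kind, so the hexyl removal offers no guide here. A step within the scatter is therefore expected in this assay, as no change at the digits printed from compound 2 to compound 3 (within the scatter). Compound 3 is estimated at 100 uM, between 30 uM and 300 uM.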

Compound 3, minimum effective concentration: 300 uM
Compound 3: the middle estimate sits 3.0-fold (0.48 log units) below what was measured; low and high end bracket the measured number.
By their numbers in this assay, from the lowest: compound 1; then compound 2; then compound 3.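

In this assay, carboxymethyl in place of carboxy at this saturated chain carbon gives a 3.0-fold higher number from compound 2 to compound 3 (0.48 log units; beyond the scatter), so the number responds to a change at the acid end of the chain and not only to the loss of hexyl. This step runs in the same direction as a 10-fold higher number from compound 1 to compound 2 (1.00 log units; beyond the scatter). Nothing measured here accounts for the shift.

The compounds shown leave open whether a longer chain ending in 2-carboxyethyl would raise the number further. They also leave open how an amine in place of the carboxylic acid would read.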